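Hydroxy in place of cyano on compound 3

The compounds below may be only part of what the source reports. "The series", "measured", "known", "first", "only" and "open" are said of these compounds alone.

Measured in a functional assay on HT-29 cells (Homo sapiens) for inhibition, read by MTT assay; a higher number here means a weaker inhibitor, a lower number a stronger inhibitor
compound 1 `COc1ccc(/C=C2\c3cc(OC)c(OC)c(OC)c3CC[C@@H]2O)cc1C#N` gives 5 nM
compound 2 `COc1ccc(/C=C2\c3cc(OC)c(OC)c(OC)c3CC[C@@H]2O)cc1O` gives 260 nM
compound 3 `COc1ccc(/C=C2\c3cc(OC)c(OC)c(OC)c3CC[C@H]2O)cc1C#N` gives 200 nM

Compound 3 lies within the scatter of compound 2 but far from compound 1. That gap, a 40-fold higher number from compound 1 to compound 3 (1.60 log units; beyond the scatter), is tied to configuration because of the fact that compounds 1 and 3 differ only in the configuration as drawn here. Compound 4 `COc1ccc(/C=C2\c3cc(OC)c(OC)c(OC)c3CC[C@H]2O)cc1O` is compound 3 with hydroxy in place of cyano on an aromatic carbon in all. The same replacement has one measured precedent in the other configuration: a 52-fold higher number from compound 1 to compound 2 (1.72 log units; beyond the scatter) in size. A large move towards a higher number in this assay is therefore expected, possibly short of that full size, as it rests on one step. The expected change is a 20-fold higher number from compound 3 to compound 4 (1.30 log units; beyond the scatter) overall. Compound 4 is estimated at 4000 nM with an expected range of 800 nM to 15000 nM in this assay.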

Compound 4, half-maximal inhibitory concentration: 790 nM
Compound 4: middle estimate off by 5.1-fold (0.70 log units), on the high side; measured number outside the range, below it.
By their numbers in this assay, from the lowest: compound 1; then compounds 3 and 2 (each within the scatter of the next); then compound 4.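

In this assay hydroxy in place of cyano raises the number in both configurations, but the size of the change does not carry over, with a 4.0-fold higher number from compound 3 to compound 4 (0.60 log units; beyond the scatter) here: the same change on two cores in this assay, a 52-fold higher number (1.72 log units; beyond the scatter) from compound 1 to compound 2 and a 4.0-fold higher number (0.60 log units; beyond the scatter) from compound 3 to compound 4, 13-fold (1.12 log units) apart, beyond the scatter of two such steps

Configuration still counts among the hydroxy compounds, though the step of a 3.0-fold higher number from compound 2 to compound 4 (0.48 log units; beyond the scatter) is smaller than a 40-fold higher number from compound 1 to compound 3 (1.60 log units; beyond the scatter) seen among the cyano compounds: the fact that compounds 2 and 4 differ only in the configuration as drawn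

Going by these compounds, whether an amine or a carboxylic acid at this position would follow cyano or hydroxy stays open. So does whether such a group would show the same dependence on configuration.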